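Phenoxymethyl for benzyloxy on the ester chain

The source may hold more compounds than are shown below. What is called first, only, known or untested is meant among the compounds shown, and "the series" means these compounds.

Three dihydropyridine esters share one core and differ only in the ester chain. Compound 1 `COC(=O)C1=C(C)NC(C)=C(C(=O)OCCCCc2ccccc2)C1c1cccc([N+](=O)[O-])c1` gives 10 nM in a functional assay on HEK293 cells for antagonist activity at Voltage-dependent L-type calcium channel subunit alpha-1C (Oryctolagus cuniculus), read by FLIPR; on this read-out lower numbers stand for stronger inhibition and higher numbers for weaker inhibition. Compound 2 `COC(=O)C1=C(C)NC(C)=C(C(=O)OCCCCc2ccc(OC)cc2)C1c1cccc([N+](=O)[O-])c1` gives 17 nM in this assay, and compound 3 `COC(=O)C1=C(C)NC(C)=C(C(=O)OCCOCc2ccccc2)C1c1cccc([N+](=O)[O-])c1` gives 9 nM. The step of a 1.7-fold higher number from compound 1 to compound 2 (0.23 log units; within the scatter) and the step of a 1.1-fold lower number from compound 1 to compound 3 (0.05 log units; within the scatter) both stay within the scatter, as does a 1.9-fold lower number from compound 2 to compound 3 (0.28 log units; within the scatter). Compound 3 thus sits at one end of the three values without being separated from either neighbour beyond the scatter.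

Compound 4 `COC(=O)C1=C(C)NC(C)=C(C(=O)OCCCOc2ccccc2)C1c1cccc([N+](=O)[O-])c1` is the next member. Its difference from compound 3 is phenoxymethyl in place of benzyloxy on a saturated chain carbon, two bonds along the chain from an oxygen next to a carbonyl group; the two compounds hold the same atoms, joined differently. Among the measured compounds shown here, the steps that bear on this are those that rework the same part of the chain: a 1.1-fold lower number from compound 1 to compound 3 (0.05 log units; within the scatter) and a 1.9-fold lower number from compound 2 to compound 3 (0.28 log units; within the scatter), each within the scatter, so rearranging the chain between the ester oxygen and the phenyl ring has so far left this assay unmoved. The expectation is therefore no step beyond the scatter, a 1.1-fold higher number from compound 3 to compound 4 (0.05 log units; within the scatter). Compound 4 is expected to give 10 nM in this assay, within a range from 4 nM to 25 nM.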

Compound 4, half-maximal inhibitory concentration: 9 nM
Beside the measured number, compound 4's estimate is 1.1-fold (0.05 log units) above it, within the range that was stated.
By their numbers in this assay, from the lowest: compounds 3, 4, 1 and 2 (each within the scatter of the next).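

In this assay, phenoxymethyl in place of benzyloxy gives no change at the digits printed from compound 3 to compound 4 (within the scatter). Among the compounds shown here, this is the first pair here that holds the same atoms, joined differently, so at this place, on a saturated chain carbon, two bonds along the chain from an oxygen next to a carbonyl group, rejoining those atoms stays within the scatter, whereas the earlier steps at this place also changed the atoms. Phenoxy, three bonds along the chain from an oxygen next to a carbonyl group, gives a 1.1-fold lower number from compound 1 to compound 4 (0.05 log units; within the scatter) in place of benzyl and a 1.9-fold lower number from compound 2 to compound 4 (0.28 log units; within the scatter) in place of 4-methoxybenzyl, which places all four compounds within the scatter of one another, and nothing measured on them speaks to the reason.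

Going by these compounds, whether an amine in place of the chain oxygen, a carboxylic acid on the phenyl ring or a longer chain would carry the number beyond the scatter remains open. Also open, on these data alone, is whether these four chains would stay this close in a read-out other than this assay.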